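A few compounds are considered here, and "the series" means these few. Any claim that something is new, unique, unknown or untested is made for them only; others in the source may bear on it.

Compound 1 `CC(=O)N1CCCC1C(=O)Nc1ccc(N2CCC(N3CCCC3C)C2)c(C)c1` gives 44.9 nM in an assay on CHO cells for displacement of a labelled ligand from histamine receptor H3 (Macaca mulatta); on this read-out lower numbers stand for stronger inhibition and higher numbers for weaker inhibition.
Compound 2 `CC1CCCN1C1CCN(c2ccc(NC(=O)C3CC3)cc2)C1` gives 9.7 nM in this assay.
Compound 3 `CC1CCCN1C1CCN(c2ccc(NC(=O)C3CC3)c(C(F)(F)F)c2)C1` gives 14.7 nM in this assay.

Among these three, compound 2 carries the lowest number. Its nearest neighbour is compound 3, and the step there, a 1.5-fold higher number from compound 2 to compound 3 (0.18 log units; within the scatter), lies within the scatter, so the two cannot be separated. Compound 1, which differs in several places, gives 44.9 nM, a higher number than compound 2 by a margin beyond the scatter.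

Compound 4 `CC1CCCN1C1CCN(c2ccc(NC(=O)C3CCCO3)cc2)C1` is the next member, and it departs from compound 2 at the amide end of the molecule: oxolan-2-yl in place of cyclopropyl on a carbonyl carbon. Among the compounds with values here, none of the measured steps touches this part of the structure; the single one-place step, from compound 2 to compound 3, concerns a substituent on the aromatic ring and says nothing direct about the acyl group. The reference point is simply that compound 2 holds the lowest number seen so far. Within the data shown here, with no step to lean on, only a modest change is expected, if any beyond the scatter. Compound 4 is therefore estimated at 15 nM, with a range from 5 nM to 45 nM. This estimate amounts to an expected step of a 1.5-fold higher number from compound 2 to compound 4 (0.19 log units; within the scatter).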

Compound 4, inhibition constant: 8.7 nM
Compound 4: the middle estimate sits 1.7-fold (0.24 log units) above what was measured; low and high end bracket the measured number.
By their numbers in this assay, from the lowest: compounds 4, 2 and 3 (each within the scatter of the next); then compound 1.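

Within the data shown here, the amide end of the molecule is varied here for the first time, and in this assay the step of a 1.1-fold lower number from compound 2 to compound 4 (0.05 log units; within the scatter) shows that oxolan-2-yl and cyclopropyl on this carbonyl carbon cannot be told apart. The two groups are not alike in what is counted: the five-membered non-aromatic ring of oxolan-2-yl has 1 hetero atom and 1 hydrogen-bond acceptor, whereas the three-membered ring of cyclopropyl is carbon only and has 0 hydrogen-bond acceptors, so this position tolerates that difference without a change beyond the scatter. No measurement at hand gives a reason for this result.

Since only these two ring groups on the carbonyl carbon can be compared, the compounds shown leave open whether an open chain such as a longer alkyl chain, a group carrying an amine or a carboxylic acid would also sit at this position without a change beyond the scatter. They also leave open whether the trifluoromethyl substituent of compound 3 would give a similar reading when combined with oxolan-2-yl on the carbonyl carbon.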